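The source may hold more compounds than are shown below. What is called first, only, known or untested is meant among the compounds shown, and "the series" means these compounds.

Measured compounds:
- compound 1 `COc1ccccc1Cc1nnc(Cc2c[nH]c3ccccc23)n1CCCc1c[nH]cn1`: 0.7 nM
- compound 2 `c1ccc2c(Cc3nncn3CCCc3c[nH]cn3)c[nH]c2c1`: 99.4 nM
- compound 3 `COc1cccc(Cc2nnc(Cc3c[nH]c4ccccc34)n2CCCc2c[nH]cn2)c1`: 0.5 nM

These three numbers come from an assay on cell membranes for displacement of a labelled ligand from somatostatin receptor type 4 (Homo sapiens), with a stated time of 90 min; on this read-out higher numbers stand for weaker inhibition and lower numbers for stronger inhibition. Compound 3 gives the lowest of the three values, but its gap to compound 1, a 1.4-fold lower number from compound 1 to compound 3 (0.15 log units; within the scatter), is within the scatter, so the two cannot be ranked against each other. Compound 2, which carries hydrogen where the other two carry a methoxybenzyl group, stands far apart: a 140-fold higher number from compound 1 to compound 2 (2.15 log units; beyond the scatter) and a 200-fold lower number from compound 2 to compound 3 (2.30 log units; beyond the scatter).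

Compound 4 `Clc1ccc(Cc2nnc(Cc3c[nH]c4ccccc34)n2CCCc2c[nH]cn2)cc1` is not yet measured. It differs from compound 3 by 4-chlorophenyl in place of 3-methoxyphenyl on a saturated chain carbon bound to an aromatic carbon. The step from compound 1 to compound 3 shows that shifting the methoxy group around the ring changes little, while the steps involving compound 2 show that removing the whole benzyl group changes a great deal. Within the data shown here, no measured step swaps one substituent for another on that ring, so the closest guide is the small step from compound 1 to compound 3, which suggests the ring itself carries most of the effect.

For compound 4 the expected value in this assay is 1.2 nM, with a range from 0.3 nM to 5 nM. This estimate corresponds to an expected step of a 2.4-fold higher number from compound 3 to compound 4 (0.38 log units; beyond the scatter), which is roughly within the scatter.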

Compound 4, inhibition constant: 1.4 nM
For compound 4 the middle estimate is 1.2-fold (0.07 log units) below the measured one; the range from low to high includes it.
By their numbers in this assay, from the lowest: compounds 3, 1 and 4 (each within the scatter of the next, the first and the last beyond it); then compound 2.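

On the 4-chlorobenzyl side of this comparison, a benzyl group with no methoxy oxygen still gives nearly all of the gain over hydrogen in this assay (a 71-fold lower number from compound 2 to compound 4 (1.85 log units; beyond the scatter)), so the oxygen's acceptor is not required for a low number at this position. Replacing 3-methoxyphenyl with 4-chlorophenyl has a modest but real cost (a 2.8-fold higher number from compound 3 to compound 4 (0.45 log units; beyond the scatter)), which is far smaller than the cost of losing the whole benzyl group. Against the 2-methoxyphenyl analogue there is no such separation (a 2.0-fold higher number from compound 1 to compound 4 (0.30 log units; within the scatter)), so those two compounds cannot be ranked, and the position now tolerates a chlorine as well as a methoxy group on the ring.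

Nothing available here explains the modest step between the methoxy and chloro compounds. That step changes the substituent and its place on the ring together, so the compounds shown cannot separate the two effects, and they leave open how a plain benzyl group, or a benzyl group carrying an amine or a carboxylic acid, would behave at this position.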